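Removal of the aryl fluoro in compound 1

The source may report more compounds than this note shows. Statements on the series, on what has been measured and on what is new or still open speak of the compounds shown alone.

Compound 1 `CCCc1nc(-c2ccccc2)c(CNCCN2CCN(c3ccccc3F)CC2)o1` stands lowest of the two measured numbers: in an assay on HEK293 cells for inhibition of Voltage-dependent T-type calcium channel subunit alpha-1G (Homo sapiens), read by fluorescence, tested at 10 uM (on this read-out higher numbers stand for more inhibition at the one concentration tested (going by the name of the read-out) and lower numbers for less inhibition), compound 1 gives 46.5%, whereas compound 2 `Cc1nc(-c2ccccc2)c(CNCCN2CCN(C(c3ccccc3)c3ccccc3)CC2)o1` gives 57.3%, a gap beyond the usual scatter. Compound 3 `CCCc1nc(-c2ccccc2)c(CNCCN2CCN(c3ccccc3)CC2)o1` is not yet measured. It differs from compound 1 by hydrogen in place of fluoro on an aromatic carbon. Going by the values given here, no measured pair shows this change, so the step from compound 1 to compound 3 is expected to be a number 1.5 percentage points lower from compound 1 to compound 3 (within the scatter), small and with no direction beyond the scatter. Compound 3 is therefore estimated at 45%, within 25% to 65%.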

Compound 3, a percentage reported as inhibition, at one concentration (the size of the read-out at that concentration, not a potency): 54.3%
Estimate against measurement, compound 3: 9.3 percentage points below; the measured number falls inside the stated range.
By their numbers in this assay, from the lowest: compounds 1, 3 and 2 (each within the scatter of the next, the first and the last beyond it).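

In this assay, going by these compounds alone, the change from 2-fluorophenyl to phenyl gives a number 7.8 percentage points higher from compound 1 to compound 3 (within the scatter) as the first reading of this change. On this one pair, the fluoro on the aromatic carbon can give way to hydrogen with the two numbers staying within the scatter of each other. No measurement at hand bears on the reason for this result.

From the compounds shown here alone, it remains open whether chloro, methoxy or trifluoromethyl at the same place would read alike. Going by these compounds, it also remains open whether hydrogen in place of fluoro reads the same way on other members.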